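From Fluoro to Chloro on the Benzyl Group

The source may hold more compounds than are shown below. What is called first, only, known or untested is meant among the compounds shown, and "the series" means these compounds.

For the measured compounds named here, compound 2 `Fc1ccc(CN2CCC(NCCSC(c3ccc(F)cc3)c3ccc(F)cc3)CC2)cc1` gives 13.3 nM in an assay on membranes from Cortex for displacement of a labelled ligand from Sigma non-opioid intracellular receptor 1 (Cavia porcellus), read by scintillation counting, with a stated time of 120 min (on this read-out higher numbers stand for weaker inhibition and lower numbers for stronger inhibition), the higher of the two numbers known so far; compound 1 `Fc1ccc(C(SCCNC2CCN(Cc3ccccc3)CC2)c2ccc(F)cc2)cc1` gives 3.81 nM. Going by the values given here, the single step between them, a 3.5-fold higher number from compound 1 to compound 2 (0.54 log units; beyond the scatter), shows that this part of the molecule is not indifferent to change. Compound 3 `Fc1ccc(C(SCCNC2CCN(Cc3ccc(Cl)cc3)CC2)c2ccc(F)cc2)cc1` carries chloro in place of fluoro on an aromatic carbon. Among the compounds with values here, no measured step exchanges one halogen for another, so that earlier step is the only guide, and it suggests at most a modest shift in either direction, or none beyond the scatter. Compound 3 is therefore expected to give 10 nM, within 4 nM to 30 nM, a step of a 1.3-fold lower number from compound 2 to compound 3 (0.12 log units; within the scatter).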

Compound 3, inhibition constant: 45.5 nM
The estimate for compound 3 lay 4.6-fold (0.66 log units) below the measured number; the whole stated range lies below it.
By their numbers in this assay, from the lowest: compound 1; then compound 2; then compound 3.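

Swapping one halogen for another on this benzyl group is not a neutral change in this assay: going from 4-fluorobenzyl to 4-chlorobenzyl gives a clear shift (a 3.4-fold higher number from compound 2 to compound 3 (0.53 log units; beyond the scatter)). Chloro in place of hydrogen gives a larger step (a 12-fold higher number from compound 1 to compound 3 (1.08 log units; beyond the scatter)), so among these three compounds, both halogens give higher numbers than hydrogen, with chloro higher than fluoro. No available evidence explains this trend. As far as these compounds go, whether bromo would continue it remains open. So does whether methyl or methoxy at the same place would also raise the number.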